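A Bromine Swapped for a Larger Group

The source may report more compounds than this note shows. Statements on the series, on what has been measured and on what is new or still open speak of the compounds shown alone.

Compound 2 `COc1ccc(/C=C/C(=O)c2ccc(NC(=O)CBr)cc2)cc1` is one of three compounds tested in a functional assay on the whole organism (strain albino) for inhibition, with Rattus norvegicus as the target, read by paw edema, with stated times of 30 min and 4 h, at a dose of 100 mg/kg by the oral route (on this read-out higher numbers stand for more inhibition at the one dose given (going by the name of the read-out) and lower numbers for less inhibition), where compound 2 gives 41%. Compound 1 `O=C(CBr)Nc1ccc(C(=O)/C=C/c2ccc(Cl)cc2)cc1` gives 59%, and compound 3 `COc1ccc(/C=C/C(=O)c2ccc(NC(=O)C(C)Br)cc2)cc1` gives 38%. Compound 2 therefore stands second of the three: a number 18 percentage points lower from compound 1 to compound 2 (beyond the scatter), while a number 3 percentage points lower from compound 2 to compound 3 (within the scatter). Compound 4 `COc1ccc(/C=C/C(=O)c2ccc(NC(=O)COc3ccc(/C(C)=N\O)cc3)cc2)cc1` differs from compound 2 at the saturated chain carbon bound to a carbonyl carbon: a group of 11 heavy atoms (8 carbon, 1 nitrogen, 2 oxygen; one six-membered aromatic ring of carbon only) in place of one bromine atom, on a saturated chain carbon bound to a carbonyl carbon. For the measured compounds named here, the only measured step at that carbon, a number 3 percentage points lower from compound 2 to compound 3 (within the scatter), is far smaller than this change, and every measured compound carries bromine, so the measured steps give little guidance and a modest drop or no change beyond the scatter seems most plausible. The step is estimated at a number 6 percentage points lower from compound 2 to compound 4 (within the scatter). Compound 4 is thus expected to give 35%, within 20% to 50%.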

Compound 4, a percentage reported as inhibition, in the whole organism at one dose (the size of the read-out at that dose, not a potency): 42%
Compound 4: middle estimate off by 7 percentage points, on the low side; the measured number falls inside the stated range.
By their numbers in this assay, from the lowest: compounds 3, 2 and 4 (each within the scatter of the next); then compound 1.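

In this assay, the bromine atom on this saturated chain carbon can be replaced by a far larger group carrying an aromatic ring, and the result is a number 1 percentage points higher from compound 2 to compound 4 (within the scatter). For the compounds shown here, all the earlier compounds carried bromine, so compound 4 is the first to show that inhibition does not depend on that atom. Nothing available explains why so large a change leaves the read-out within the scatter. Still open, going by these compounds, is whether an amine or a carboxylic acid at this carbon would hold the read-out at this level. The same replacement on compound 1, with its chloro group, also remains an open case.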